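The source may report more compounds than this note shows. Statements on the series, on what has been measured and on what is new or still open speak of the compounds shown alone.

Compound 1, `CCCCCOC(=O)N1CCN(C(=O)[C@H](CCC(=O)O)NC(=O)c2cc(N3CCC(C(=O)N(CC)CC)CC3)nc(-c3ccccc3)n2)CC1`, is the starting point. In an ADME assay on microsomes from liver (Homo sapiens) for metabolic stability (on this read-out higher numbers stand for a more stable compound and lower numbers for a less stable compound), compound 1 gives > 80%, which is a limit of the assay rather than a number. Compound 2, `CCCCCOC(=O)N1CCN(C(=O)[C@H](CCC(=O)O)NC(=O)c2cc(N3CCC(OCCO)CC3)nc(-c3ccccc3)n2)CC1`, carries 2-hydroxyethoxy in place of diethylcarbamoyl on a saturated ring carbon; in this assay compound 2 gives > 80%, again a limit. Compound 3, `CCCCCOC(=O)N1CCN(C(=O)[C@H](CCC(=O)O)NC(=O)c2cc(N3CCC(CNC)CC3)nc(-c3ccccc3)n2)CC1`, carries (methylamino)methyl in place of diethylcarbamoyl on a saturated ring carbon, and in this assay compound 3 gives > 80%, also a limit. The steps a step that the two limits leave unreadable from compound 1 to compound 2, a step that the two limits leave unreadable from compound 1 to compound 3 and a step that the two limits leave unreadable from compound 2 to compound 3 show no size at all because of the limit of > 80% in this assay, at which 3 of the 3 values shown sit. Compound 4, `CCCCCOC(=O)N1CCN(C(=O)[C@H](CCC(=O)O)NC(=O)c2cc(N3CCC(C(N)=O)CC3)nc(-c3ccccc3)n2)CC1`, differs from compound 1 by amino in place of diethylamino on a carbonyl carbon; cut one bond further out, the same difference reads diethylcarbamoyl to carbamoyl. Among the compounds with values here, no measured step shares this change, and none of them is readable, so neither a direction nor a size can be drawn from them. Since every measured compound sits at the limit, compound 4 is expected to sit there as well, and the step that the limit leaves unreadable from compound 1 to compound 4 is expected to stay within the scatter. Compound 4 is estimated at 88%, between 70% and 100%.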

Compound 4, percent of the compound remaining: > 80%
Compound 4: a limit, no number (the forecaster's own chance of this, stated with the estimate: 80%); the middle value is on the limit's open side.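

In this assay compound 4 gives > 80%, again a limit, so its steps to compound 1, compound 2 and compound 3 cannot be read: the limit of > 80% in this assay, at which 4 of the 4 values shown sit. On these data alone, whether these four compounds differ at all in stability, and by how much, stays open.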